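Three Cytotoxicity Values and a Fourth Compound Expected

The source may hold more compounds than are shown below. What is called first, only, known or untested is meant among the compounds shown, and "the series" means these compounds.

Compound 1, `Cn1nnnc1SCC(=O)N/N=c1/scc(-c2ccc(F)cc2)n1-c1ccccc1`, gives 113 ug/mL in an ADME assay on NIH3T3 cells (Mus musculus) for cytotoxicity, read by MTT assay, with a stated time of 24 h; a lower number here means a stronger inhibitor, a higher number a weaker inhibitor.
Compound 2, `Cn1cnnc1SCC(=O)N/N=c1/scc(-c2ccc(C#N)cc2)n1-c1ccccc1`, gives 153 ug/mL in this assay.
Compound 3, `Cn1nnnc1SCC(=O)N/N=c1/scc(-c2ccc(C#N)cc2)n1-c1ccccc1`, gives 213 ug/mL in this assay.

The three measured compounds share a core and differ in two places. Compound 3 and compound 1 differ only in one change, (fluoro in place of cyano on an aromatic carbon), and this change brought a 1.9-fold lower number from compound 3 to compound 1 (0.28 log units; within the scatter). Compound 2 and compound 3 differ only in their cores, (4-methyl-4H-1,2,4-triazol-3-yl in place of 1-methyl-1H-tetrazol-5-yl on a sulfur), and that difference corresponds to a 1.4-fold higher number from compound 2 to compound 3 (0.14 log units; within the scatter). Compound 2 stands second highest of the three numbers, nearest to compound 1 and furthest from compound 3, and all three numbers lie within the scatter of one another, so no order among them can be claimed.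

Compound 4, `Cn1cnnc1SCC(=O)N/N=c1/scc(-c2ccc(F)cc2)n1-c1ccccc1`, has not yet been measured in this assay. It differs from compound 2 by fluoro in place of cyano on an aromatic carbon, which is the same change as the one made from compound 3 to compound 1, placed on the same kind of aromatic carbon; among the compounds shown it occurs twice in all.

Resting on the only measured instance of this change, which gave a 1.9-fold lower number from compound 3 to compound 1 (0.28 log units; within the scatter), compound 4 is expected to show a step of a 1.7-fold lower number from compound 2 to compound 4 (0.23 log units; within the scatter). Compound 4 is therefore estimated at 90 ug/mL, with a range from 45 ug/mL to 180 ug/mL expected to hold most repeated measurements.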

Compound 4, half-maximal inhibitory concentration: 65 ug/mL
Estimate against measurement, compound 4: 1.4-fold (0.14 log units) above, within the range that was stated.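

In this assay, fluoro in place of cyano on an aromatic carbon gave a 2.4-fold lower number from compound 2 to compound 4 (0.37 log units; beyond the scatter), and set beside the earlier step, the change carried from one core to the other with no difference that can be told apart: the same change on two cores in this assay, a 1.9-fold lower number (0.28 log units; within the scatter) from compound 3 to compound 1 and a 2.4-fold lower number (0.37 log units; beyond the scatter) from compound 2 to compound 4, 1.2-fold (0.10 log units) apart, within the scatter of two such steps. The exchange on the sulfur, read with fluoro on the aromatic carbon, gave a 1.7-fold lower number from compound 1 to compound 4 (0.24 log units; within the scatter), and this step likewise agrees with its counterpart read with cyano: the same change on two cores in this assay, a 1.4-fold higher number (0.14 log units; within the scatter) from compound 2 to compound 3 and a 1.7-fold higher number (0.24 log units; within the scatter) from compound 4 to compound 1, 1.2-fold (0.10 log units) apart, within the scatter of two such steps. Within the data shown here, each change thus kept a similar size on both of its partners in these four compounds, but each comparison rests on a single pair of steps, only the step from cyano to fluoro on the triazolyl partner lies beyond the scatter, and nothing here shows that either change would carry to a core outside this set.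

The compounds shown leave open whether the same agreement would hold with a chloro, methoxy or carboxylic acid group in place of fluoro or cyano on that aromatic carbon. They also leave open what an amine or a longer chain in place of the methyl-bearing groups on the sulfur would do to these steps.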